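Adding a third methoxy to compound 2

The source may report more compounds than this note shows. Statements on the series, on what has been measured and on what is new or still open speak of the compounds shown alone.

Measured in a functional assay on KM12 cells (Homo sapiens) for antiproliferative activity; on this read-out higher numbers stand for weaker inhibition of growth and lower numbers for stronger inhibition of growth:
Compound 1 `COc1ccc(-c2nc3cc(F)ccc3s2)cc1C`: 18600 nM
Compound 2 `COc1ccc(-c2nc3cc(F)ccc3s2)cc1OC`: 290 nM

Compound 2 holds the lower of the two numbers. Compound 3 `COc1ccc(-c2nc3cc(F)ccc3s2)c(OC)c1OC` differs from it by methoxy in place of hydrogen on an aromatic carbon, ortho to a large group and ortho to a methoxy group. For the measured compounds named here, only one measured step bears on this, the large 64-fold lower number from compound 1 to compound 2 (1.81 log units; beyond the scatter), which lies beyond the scatter. Going by the values given here, that step exchanged methyl for methoxy, whereas here a hydrogen leaves, so it shows only that one ring substituent can move this read-out far. Among the compounds with values here, with compound 2 at 290 nM, the lowest number so far, a clear step to a higher number is expected in this assay. The expected step is a 10-fold higher number from compound 2 to compound 3 (1.01 log units; beyond the scatter). For compound 3 the estimate is 3000 nM, with an expected range from 350 nM to 25000 nM.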

Compound 3, concentration for 50% growth inhibition: 14200 nM
Estimate against measurement, compound 3: 4.7-fold (0.68 log units) below; low and high end bracket the measured number.
By their numbers in this assay, from the lowest: compound 2; then compounds 3 and 1 (each within the scatter of the next).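

In this assay, methoxy in place of hydrogen on this aromatic carbon, ortho to a large group and ortho to a methoxy group, gives a 49-fold higher number from compound 2 to compound 3 (1.69 log units; beyond the scatter). The earlier step exchanged one group for another, whereas this one shows that filling a carbon that held only hydrogen can also move the read-out by a large step, here towards weaker inhibition of growth. Methoxy therefore goes with stronger inhibition in the earlier step and weaker inhibition here, so the result of adding this group depends on where it stands on the ring.

Nothing available accounts for the higher number at this position. On these data alone, whether it is particular to methoxy or would follow any group on this carbon stays open; a hydroxyl or an amine there would help to decide.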